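A few compounds are considered here, and "the series" means these few. Any claim that something is new, unique, unknown or untested is made for them only; others in the source may bear on it.

Three compounds sharing the core of compound 1 `Cc1csc(N)c1C(=O)c1ccc(Cl)cc1` have been tested in an assay on CHO cells for displacement of a labelled ligand from adenosine receptor A3 (Homo sapiens), read by scintillation counting, tested at 10 uM; on this read-out higher numbers stand for more inhibition at the one concentration tested (going by the name of the read-out) and lower numbers for less inhibition. In this assay compound 1 gives 1%. Compound 2 `Cc1sc(N)c(C(=O)c2ccc(Cl)cc2)c1-c1ccccc1` gives 1% in this assay, and compound 3 `CC(C)(C)Cc1c(-c2ccccn2)sc(N)c1C(=O)c1ccc(Cl)cc1` gives 1% in this assay. Compound 3 thus stands level with compound 1 and with compound 2 at the digits shown, both within the scatter. Compound 4 `COc1cccc(-c2sc(N)c(C(=O)c3ccc(Cl)cc3)c2CC(C)(C)C)c1` has not yet been measured; it differs from compound 3 by 3-methoxyphenyl in place of pyridin-2-yl on an aromatic carbon. Going by the values given here, no step between measured compounds is available to judge this change, and every value seen so far sits at the same low level, so the expected step is a number 1 percentage points higher from compound 3 to compound 4 (within the scatter), none beyond the scatter. Compound 4 is accordingly estimated to give about 2% in this assay, within a range from 0% to 12%.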

Compound 4, a percentage reported as inhibition, at one concentration (the size of the read-out at that concentration, not a potency): 1%
Estimate against measurement, compound 4: 1 percentage points above; the measured number falls inside the stated range.
By their numbers in this assay, from the lowest: compounds 1, 2, 3 and 4 (each within the scatter of the next).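

Putting 3-methoxyphenyl in place of pyridin-2-yl on the aromatic carbon next to the ring sulfur gives no change at the digits printed from compound 3 to compound 4 (within the scatter) in this assay. Going by these compounds alone, this is the first step that can be read at this position, and it shows that exchanging a ring with one hetero atom for a ring of carbon only, bearing a methoxy group, leaves the read-out at the same low level. Nothing available explains this result. Going by these compounds, whether an amine or a carboxylic acid on this carbon would raise the inhibition remains open.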